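Adding an ethyl group to compound 2

The source may hold more compounds than are shown below. What is called first, only, known or untested is meant among the compounds shown, and "the series" means these compounds.

Compound 1 (`CCCSc1nc(C(C)c2c(F)cccc2Cl)cc(=O)[nH]1`), compound 2 (`CCCCSc1nc(C(C)c2c(F)cccc2Cl)cc(=O)[nH]1`) and compound 3 (`CC(c1cc(=O)[nH]c(SC2CCCC2)n1)c1c(F)cccc1Cl`) differ only in the group on sulfur. In an ADME assay on MT4 cells (Homo sapiens) for activation, read by MTT assay (a lower number here means that less compound is tolerated, a higher number that more compound is tolerated), compound 1 gives > 75000 nM as a limit. Compound 2 gives > 73000 nM as a limit. Compound 3 gives > 71000 nM as a limit. So compound 2 has no exact number, and neither do the other two.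

Compound 4 (`CCCCSc1nc(C(C)c2c(F)cccc2Cl)c(CC)c(=O)[nH]1`) keeps the butylsulfanyl group of compound 2 and differs by ethyl in place of hydrogen on an aromatic carbon in an ethyl in place of hydrogen on an aromatic carbon.

The nearest evidence is a step that the two limits leave unreadable from compound 1 to compound 2 and a step that the two limits leave unreadable from compound 1 to compound 3 and a step that the two limits leave unreadable from compound 2 to compound 3 on the sulfur side only, with no readable size. No change beyond the scatter is therefore expected in this assay, and the expected step is an at least 1.0-fold lower number from compound 2 to compound 4 (0.01 log units; that floor lies within the scatter) as a rough guess. The estimate for compound 4 is 70000 nM within an expected range from 30000 nM to 120000 nM in this assay.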

Compound 4, half-maximal cytotoxic concentration: > 3000 nM
Compound 4 ended at the assay's limit; the forecaster's own chance of this, stated with the estimate: 60%; the middle value lies beyond the limit too.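

Going by these compounds alone, compound 2 and compound 4 each give only a limit in this assay, so no step between them can be read. The compounds shown leave open whether ethyl in place of hydrogen on an aromatic carbon changes this number at all, and in which direction.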